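Working notes: hydrogen for methyl on compound 3

The source may hold more compounds than are shown below. What is called first, only, known or untested is meant among the compounds shown, and "the series" means these compounds.

Readings in a functional assay on KB 3-1 cells (Homo sapiens) for cytotoxicity, read by MTT assay, with a stated time of 68 h (a higher number here means a weaker inhibitor, a lower number a stronger inhibitor), so far:
Compound 1 `O=C(Nc1cccc(-c2ccccc2F)c1)C(Cl)Cl` gives 48300 nM (a number)
Compound 2 `O=C(Nc1cccc(-c2ccc(F)cc2)c1)C(Cl)Cl` gives 26200 nM (a number)
Compound 3 `Cc1cccc(-c2cccc(NC(=O)C(Cl)Cl)c2)c1` gives > 50000 nM (a limit of the assay, not a number)

Compound 3 stands at the limit of > 50000 nM in this assay, at which 1 of the 3 values shown sits (a limit, so its true position is not known).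

Compound 1 at 48300 nM and compound 2 at 26200 nM lie within the usual scatter of each other, so no order can be drawn between them.

The next compound is compound 4 `O=C(Nc1cccc(-c2ccccc2)c1)C(Cl)Cl` and it differs from compound 3 by one change: hydrogen in place of methyl on an aromatic carbon (on a six-membered aromatic ring of carbon only, meta to a large group).

For the measured compounds named here, no measured step isolates this change, so the expectation rests on the neighbouring values alone. In this assay a small step towards a lower number is expected, quite possibly none beyond the scatter, since compound 2 at 26200 nM is the lowest reading so far.

The expected step is an at least 1.4-fold lower number from compound 3 to compound 4 (0.15 log units; that floor lies within the scatter) (an estimate, uncertain given the limit at its start).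

The estimate for compound 4 is 35000 nM (expected range 15000 nM to 60000 nM) and a reading at the limit would not surprise.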

Compound 4, half-maximal inhibitory concentration: 46800 nM
Beside the measured number, compound 4's estimate is 1.3-fold (0.13 log units) below it; low and high end bracket the measured number.
By their numbers in this assay, from the lowest: compounds 2, 4 and 1 (each within the scatter of the next). At a limit, above all of these: compound 3.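

Hydrogen in place of methyl, on a six-membered aromatic ring of carbon only and meta to a large group, gives in this assay an at least 1.0-fold lower number from compound 3 to compound 4 (0.02 log units; that floor lies within the scatter), the first reading of this change in the series, though it sets only a floor and leaves the true size of the step unknown. The reading for compound 3 is a limit of the assay, not a number: the limit of > 50000 nM in this assay, at which 1 of the 4 values shown sits. Compound 4 also provides a measured hydrogen reference for the two fluoro compounds, with hydrogen in place of fluoro giving a 1.8-fold higher number from compound 2 to compound 4 (0.25 log units; within the scatter) and a 1.0-fold lower number from compound 1 to compound 4 (0.01 log units; within the scatter), so neither fluoro compound can be told apart from the hydrogen compound in this assay.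

The compounds shown leave open how far the true value of compound 3 lies from that of compound 4, and so whether methyl at this place changes the reading at all. They also leave open whether a different group here, such as an amine or a carboxylic acid, would move the number beyond the scatter, and whether any change to the shared core would do so.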